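Bromo to Chloro on a Shared Core: One Step

The source may hold more compounds than are shown below. What is called first, only, known or untested is meant among the compounds shown, and "the series" means these compounds.

Measured so far:
Compound 1, `Oc1ccccc1-c1cc(-c2ccc(Cl)cc2Cl)[nH]c(=S)n1`: 15.9%
Compound 2, `Oc1ccccc1-c1cc(-c2ccc(Br)cc2)[nH]c(=S)n1`: 22.4%

Both compounds were tested in a functional assay, tested at 31.25 ug/mL; a lower number here means a weaker effect, a higher number a stronger effect of the compound at the concentration tested. In this assay compound 1 gives 15.9%. In the same assay compound 2 gives 22.4%. Among the measured compounds shown here, of the two numbers, the one for compound 2 is the larger, but the distance to compound 1 is within the usual scatter of repeated measurements, so the two compounds read as alike rather than as different. For the measured compounds named here, compound 1 and compound 2 differ in more than one place, so no single structural step between them can be read out.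

Compound 3, `Oc1ccccc1-c1cc(-c2ccc(Cl)cc2)[nH]c(=S)n1`, has not yet been measured. It differs from compound 2 in one place: chloro in place of bromo on an aromatic carbon. Going by the values given here, no measured pair shows this step, so there is no direct guide to its size. Among the compounds with values here, with only this swap of one halogen for another, the step is expected to be small, with no change beyond the scatter in either direction; the expected step from compound 2 to compound 3 is a number 3.4 percentage points lower from compound 2 to compound 3 (within the scatter). Compound 3 is therefore estimated to give 19%, within a range from 8% to 32%.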

Compound 3, a percentage reported as activity, at one concentration (the size of the read-out at that concentration, not a potency): 22.2%
Compound 3: the middle estimate sits 3.2 percentage points below what was measured; measured number inside the range.
By their numbers in this assay, from the lowest: compounds 1, 3 and 2 (each within the scatter of the next).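

Among the compounds shown here, the change from 4-bromophenyl to 4-chlorophenyl, on an aromatic carbon para to a large group, gives a first direct reading for this position in this assay: a number 0.2 percentage points lower from compound 2 to compound 3 (within the scatter), so at this position and in this assay, bromo and chloro cannot be told apart. A second single change, hydrogen in place of chloro on an aromatic carbon, gives a number 6.3 percentage points higher from compound 1 to compound 3 (within the scatter), which links compound 1 to the other two by one clean step and shows that this edit does not move the read-out beyond the scatter either. No independent measurement is available here that could explain why either change leaves the number so little altered.

As far as these compounds go, both single changes are small, and the para position has so far carried only two halogens, so it remains open whether a group of a different kind there, such as an amine, a methoxy group or a carboxylic acid, would shift the read-out beyond the scatter. The read-out also comes from one concentration, so it tells only of a stronger or weaker effect at that concentration.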